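The compounds below may be only part of what the source reports. "The series", "measured", "known", "first", "only" and "open" are said of these compounds alone.

In a functional assay on L1210 cells (Mus musculus) for antiproliferative activity, with a stated time of 4 h (a higher number here means a weaker inhibitor, a lower number a stronger inhibitor), compound 1 (`O=C1NC(=O)c2c1c1c(O)ccc(O)c1c1[nH]c3ccccc3c21`) gives 1100 nM and compound 2 (`Cc1ccc2[nH]c3c4c(O)ccc(O)c4c4c(c3c2c1)C(=O)NC4=O`) gives 600 nM, so compound 2 stands level with compound 1 within the scatter. Within the data shown here, the one measured step, a 1.8-fold lower number from compound 1 to compound 2 (0.26 log units; within the scatter), is methyl in place of hydrogen on an aromatic carbon. Compound 3 (`Cc1ccc2[nH]c3c4c(OS(=O)(=O)O)ccc(O)c4c4c(c3c2c1)C(=O)NC4=O`) differs from compound 2 by sulfo in place of hydrogen on an oxygen on an aromatic ring. Among the measured compounds shown here, no measured step covers a change at that oxygen, so the series gives no size for it. A moderate move in this assay towards a higher number is expected, on weak grounds, as a 2.5-fold higher number from compound 2 to compound 3 (0.40 log units; beyond the scatter). For compound 3 the estimated value is 1500 nM, with an expected range of 400 nM to 8000 nM.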

Compound 3, half-maximal inhibitory concentration: 25600 nM
Compound 3: middle estimate off by 17-fold (1.23 log units), on the low side; measured number above the stated range.
By their numbers in this assay, from the lowest: compounds 2 and 1 (each within the scatter of the next); then compound 3.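

Hydroxy to sulfooxy, on an oxygen on an aromatic ring, gives the first step in the series beyond the scatter in this assay: a 43-fold higher number from compound 2 to compound 3 (1.63 log units; beyond the scatter). This oxygen therefore does not tolerate every replacement of its hydrogen, and the step is large, while a 1.8-fold lower number from compound 1 to compound 2 (0.26 log units; within the scatter) stays within the scatter. Nothing at hand bears on the cause of this step.

Still open, from the compounds shown here alone, is whether the step belongs to sulfo itself or to any replacement of this hydrogen. A methyl ether or an acetate ester at this oxygen would separate the two.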